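A few compounds are considered here, and "the series" means these few. Any claim that something is new, unique, unknown or untested is made for them only; others in the source may bear on it.

Measured compounds:
Compound 1 `CC1(Cc2ccccc2)CC(S(=O)(=O)c2ccccc2)=C(c2ccc(/C(N)=N/O)cc2)O1` gives 94600 nM in an ADME assay on THP-1 cells (Homo sapiens) for cytotoxicity, read by flow cytometry, with a stated time of 72 h; on this read-out higher numbers stand for weaker inhibition and lower numbers for stronger inhibition.
Compound 2 `N/C(=N\O)c1ccc(Nc2ccc(C3=C(S(=O)(=O)c4ccc(/C(N)=N/O)cc4)CC(c4ccccc4)(c4ccccc4)O3)cc2)cc1` gives 48900 nM in this assay.
Compound 3 `CC1(Cc2ccccc2)CC(S(=O)(=O)c2ccc(/C(N)=N/O)cc2)=C(c2ccc(Nc3ccc(/C(N)=N/O)cc3)cc2)O1` gives 9800 nM in this assay.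

Among these three numbers compound 1 stands highest. Its nearest neighbour is compound 2, whose value lies within the usual scatter of it, so no order between the two can be claimed. Compound 3 sits beyond the scatter below compound 1, at the far end of the small set.

Compound 4 `CC1(Cc2ccccc2)CC(S(=O)(=O)c2ccc(Nc3cccc(/C(N)=N/O)c3)cc2)=C(c2ccc(/C(N)=N/O)cc2)O1` has not yet been measured. Relative to compound 1 it carries a group of 11 heavy atoms (7 carbon, 3 nitrogen, 1 oxygen; one six-membered aromatic ring of carbon only) in place of a hydrogen atom, on an aromatic carbon. Going by the values given here, no step between two measured compounds matches this change exactly, so the expectation rests on the values alone: compound 3, the most heavily substituted member, gives 9800 nM, while compound 1 gives 94600 nM. A move toward lower numbers, of moderate size, is therefore expected in this assay from compound 1 to compound 4, a 2.7-fold lower number from compound 1 to compound 4 (0.43 log units; beyond the scatter). Compound 4 is estimated at 35000 nM, with a range from 12000 nM to 95000 nM.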

Compound 4, half-maximal inhibitory concentration: 46600 nM
The estimate for compound 4 lay 1.3-fold (0.12 log units) below the measured number; the measured number falls inside the stated range.
By their numbers in this assay, from the lowest: compound 3; then compounds 4, 2 and 1 (each within the scatter of the next, the first and the last beyond it).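

Going by these compounds alone, compound 4 supplies the first change in this set that can be read at a single place: a group of 11 heavy atoms (7 carbon, 3 nitrogen, 1 oxygen; one six-membered aromatic ring of carbon only) in place of a hydrogen atom, on an aromatic carbon, gives a 2.0-fold lower number from compound 1 to compound 4 (0.31 log units; beyond the scatter) in this assay as a modest step. Substitution at this position, para to a large group, therefore does move the number, though only just past the usual scatter. Nothing measured here accounts for the step.

The compounds shown leave open whether a simple amine or a carboxylic acid on the same aromatic carbon would move the number as far as this larger group does. They also leave open whether the same replacement would give a step of similar size on the core of compound 2.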